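A few compounds are considered here, and "the series" means these few. Any claim that something is new, unique, unknown or untested is made for them only; others in the source may bear on it.

Compound 1 `COc1ccc(Nc2nc(/C=C/c3ccccc3)nc3ccsc23)cc1`: > 1000000 nM
Compound 2 `COc1ccc(Nc2nc(/C=C/c3cc(OC)c(OC)c(OC)c3)nc3ccsc23)cc1`: 279000 nM

Going by the values given here, in a functional assay on L02 cells (Homo sapiens) for inhibition, read by Griess assay, with stated times of 1 h and 24 h (on this read-out higher numbers stand for weaker inhibition and lower numbers for stronger inhibition), compound 2 gives 279000 nM, the only number measured here. For compound 1 the assay reports a limit, > 1000000 nM. Compound 3 `COc1cc(/C=C/c2nc(OCc3ccccc3)c3sccc3n2)cc(OC)c1OC` has not yet been tested; it differs from compound 2 at one position: benzyloxy in place of (4-methoxyphenyl)amino on an aromatic carbon. Among the compounds with values here, no measured pair shows what this exchange does, so the expected step is a modest weakening, a 1.6-fold higher number from compound 2 to compound 3 (0.21 log units; within the scatter), within wide uncertainty. Compound 3 is therefore estimated at 450000 nM, ranging from 120000 nM to 1000000 nM, and a limit rather than a number remains possible.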

Compound 3, half-maximal inhibitory concentration: > 1000000 nM
Compound 3 was reported as a limit; the forecaster's own chance of this, stated with the estimate: 40%; middle value at least 2.2-fold (0.34 log units) from the limit.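

Replacing (4-methoxyphenyl)amino with benzyloxy, on the aromatic carbon next to the ring nitrogen, gives an at least 3.5-fold higher number from compound 2 to compound 3 (0.55 log units; beyond the scatter) in this assay, so this position does affect the read-out. The exchange also replaces a group with a hydrogen-bond donor by one with none. The true size of the step stays unknown because compound 3 is reported only as a limit: the limit of > 1000000 nM in this assay, at which 2 of the 3 values shown sit.

The compounds shown leave open whether the linking nitrogen or the methoxy group on the ring matters more. Comparing benzylamino or unsubstituted phenylamino at this position would help separate the two.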